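This account rests on a few compounds, and the source may have more. Where it says the series, first, only, none or still open, it means among the compounds named here.

Measured compounds:
compound 1 `N#Cc1nc(-c2ccc(OCCCO)c(C(F)(F)F)c2)cc2[nH]cnc12` — 63 nM
compound 2 `CCOc1ccc(-c2cc3c(ncn3CCCN(C)C)c(C#N)n2)cc1C(F)(F)F` — 27 nM
compound 3 `CCOc1ccc(-c2cc3c(ncn3C)c(C#N)n2)cc1C(F)(F)F` — 40 nM

In an assay on isolated protein for inhibition of cathepsin S (Homo sapiens), read by fluorescence (on this read-out higher numbers stand for weaker inhibition and lower numbers for stronger inhibition), compound 3 gives 40 nM, the middle of the three numbers; compound 2 with 27 nM and compound 1 with 63 nM both lie within the scatter of it, so the three compounds cannot be told apart on these measurements.

Compound 4 `Cn1cnc2c(C#N)nc(-c3ccc(OC4CCNCC4)c(C(F)(F)F)c3)cc21` differs from compound 3 in one place: piperidin-4-yl in place of ethyl on an oxygen on an aromatic ring. Within the data shown here, only one measured step is available, and it concerns a different position of the shared core: a 1.5-fold higher number from compound 2 to compound 3 (0.17 log units; within the scatter). Among the measured compounds shown here, compound 1 carries another group on the aryl ether oxygen and a different substitution on the ring nitrogen, so its number cannot be tied to the ether change alone; it shows only that a different ether group gives a number within the scatter of compound 3. For the measured compounds named here, no measured pair isolates an exchange on the ether oxygen. The expectation for compound 4 is therefore a step no larger than the scatter, a 1.1-fold lower number from compound 3 to compound 4 (0.06 log units; within the scatter), with a wide uncertainty. Compound 4 is estimated at 35 nM, in a range from 10 nM to 120 nM.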

Compound 4, half-maximal inhibitory concentration: 316 nM
Estimate against measurement, compound 4: 9.0-fold (0.96 log units) below, and the stated range ends below it.
By their numbers in this assay, from the lowest: compounds 2, 3 and 1 (each within the scatter of the next, the first and the last beyond it); then compound 4.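

In this assay the exchange of ethyl for piperidin-4-yl on the oxygen on the aromatic ring gives a 7.9-fold higher number from compound 3 to compound 4 (0.90 log units; beyond the scatter) and so weakens inhibition beyond the scatter. The only earlier step, a 1.5-fold higher number from compound 2 to compound 3 (0.17 log units; within the scatter) at a different place on the shared core, stayed within the scatter, so this is the first sign among these compounds that the number can respond to a single exchange, and the first isolated reading of the group on the ether oxygen. No measurement given here accounts for the step, so it can be described but not explained.

The compounds shown do not separate the contribution of the ring carbons from that of the ring nitrogen and its hydrogen: cyclohexyl on the same oxygen would keep a six-membered ring without the nitrogen, while an open-chain amine would keep the nitrogen without the ring. Among these compounds, whether the weaker inhibition belongs to piperidin-4-yl alone or extends to other groups on this oxygen also remains open, since this is the only exchange there that can be read on its own.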